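From cyclopropyl to cyclopropylmethyl on a shared core

The compounds below may be only part of what the source reports. "The series", "measured", "known", "first", "only" and "open" are said of these compounds alone.

Measured in a functional assay (aorta) with Rattus norvegicus as the target; a higher number here means that more compound is needed for the effect, a lower number that less compound is needed:
Compound 1 `CCC(C)NC1=NS(=O)(=O)c2cc(F)ccc2N1`: 39.2 uM
Compound 2 `O=S1(=O)NC(NC2CC2)=Nc2ccc(F)cc21`: > 300 uM, a limit of the assay

Compound 2 sits at the limit of > 300 uM in this assay, at which 1 of the 2 values shown sits, which is a limit and not a number. Compound 1, built on the same core, gives a true number, 39.2 uM.

The next compound, compound 3 `O=S1(=O)NC(NCC2CC2)=Nc2ccc(F)cc21`, keeps that core and changes one group of compound 2: cyclopropylmethyl in place of cyclopropyl on an amine nitrogen. Going by the values given here, no measured pair shows this change, so the expectation rests on thin ground. Among the compounds with values here, the only guide is compound 1 at 39.2 uM, which has an open chain on that nitrogen rather than a ring. In this assay, the expected direction is toward less compound needed, by more than the usual scatter, which would bring compound 3 into the neighbourhood of compound 1. The estimated change is an at least 6.6-fold lower number from compound 2 to compound 3 (0.82 log units; beyond the scatter). For compound 3 the estimated value is 45 uM, with an expected range of 12 uM to 170 uM.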

Compound 3, concentration for half-maximal effect: 146 uM
Estimate against measurement, compound 3: 3.2-fold (0.51 log units) below; measured number inside the range.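

In this assay, cyclopropylmethyl in place of cyclopropyl on an amine nitrogen gives an at least 2.0-fold lower number from compound 2 to compound 3 (0.31 log units; beyond the scatter), so this position responds to a very small change in its group. Until now, only the open chain of compound 1 had given a true number on this core, and compound 3 shows that a group carrying the three-membered ring can give one too, with 4 heavy atoms in place of 3. From the compounds shown here alone, the real size of the step stays unknown because compound 2 is a limit and not a number: the limit of > 300 uM in this assay, at which 1 of the 3 values shown sits.

The compounds shown leave open whether the trend goes on with a longer chain, such as cyclopropylethyl, or with a larger ring, such as cyclobutylmethyl. They also cannot tell whether the ring itself matters on this nitrogen, which would take a direct comparison with an open chain of the same length, such as n-butyl, or how a hydroxyl group on the chain would read in this assay.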